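The compounds below may be only part of what the source reports. "The series", "measured", "known", "first", "only" and "open" are said of these compounds alone.

Of the compounds shown here, three built on one shared core have so far been measured in a functional assay on HEK293 cells for agonist activity at D(4) dopamine receptor (Homo sapiens), read by FLIPR; a lower number here means a smaller maximal response, a higher number a larger maximal response. Compound 1 `O=C(CN1CCC(c2cccc[n+]2[O-])CC1)Nc1cccc(Cl)c1` gives 76%, the highest of the three numbers. Compound 2 `Cc1ccc(C(=O)NCN2CCC(c3cccc[n+]3[O-])CC2)cc1C` gives 65%, which lies below compound 1 beyond the scatter. Compound 3 `CC(C)Oc1cccc(NC(=O)CN2CCC(c3cccc[n+]3[O-])CC2)c1` gives 48%, the furthest from compound 1. Only one pair of these compounds differs in a single place: a number 28 percentage points lower from compound 1 to compound 3 (beyond the scatter), with isopropoxy in place of chloro on an aromatic carbon.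

Compound 4 `Cc1cc(F)ccc1NC(=O)CN1CCC(c2cccc[n+]2[O-])CC1` has not yet been measured in this assay. It differs from compound 1 in one place: 4-fluoro-2-methylphenyl in place of 3-chlorophenyl on an amide-type nitrogen. The step from compound 1 to compound 3 bears on this change most directly, since it also alters the aromatic ring attached to the amide-type nitrogen and was modest in size, lowering the maximal response beyond the scatter. Compound 2 carries a methyl-bearing ring as well, but its linker also differs, so only its value is noted. A change of the aryl group on this nitrogen has so far gone with a lower number, and compound 4 is therefore expected to fall below compound 1 by a modest margin, a number 16 percentage points lower from compound 1 to compound 4 (beyond the scatter). For compound 4 the estimate in this assay is 60%, with a range from 42% to 78%.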

Compound 4, largest response reached (reported as efficacy), in percent of the reference or control that the assay uses: 84%
For compound 4 the middle estimate is 24 percentage points below the measured one; measured number above the stated range.
By their numbers in this assay, from the lowest: compound 3; then compound 2; then compounds 1 and 4 (each within the scatter of the next).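

In this assay, 4-fluoro-2-methylphenyl in place of 3-chlorophenyl on the amide-type nitrogen gives a number 8 percentage points higher from compound 1 to compound 4 (within the scatter) and so produces no change that can be told from the scatter. Among the compounds shown here, the only earlier single-place change at this aryl group, a number 28 percentage points lower from compound 1 to compound 3 (beyond the scatter), lay beyond the scatter, so the present step shows that replacing the aryl group on this nitrogen need not go with a lower number, even with the chlorine gone and two other groups on the ring. Compound 3 therefore stands against any general rule for this position, and the data give no reason for the contrast between the two steps.

The compounds shown leave open what the fluoro and methyl groups each contribute, as the two enter together and neither appears alone on this ring. Also open, on these data alone, is how this assay's maximal response would read with a nitrile, a carboxylic acid or an amine on the ring, or with a cyclohexyl group replacing the aromatic ring on this nitrogen.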